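The source may hold more compounds than are shown below. What is called first, only, known or untested is meant among the compounds shown, and "the series" means these compounds.

Measured in a functional assay on HCT-8 cells (Homo sapiens) for cytotoxicity; a higher number here means that more compound is needed for the effect, a lower number that less compound is needed:
Compound 1 `COC1=C(C)C(=O)/C(=C(O)/C=C/c2ccccc2OC)C(=O)C1(C)C`: 4.1 ug/mL
Compound 2 `COC1=C(C)C(=O)/C(=C(O)/C=C/c2ccc(C)cc2)C(=O)C1(C)C`: 4.1 ug/mL
Compound 3 `COC1=C(C)C(=O)/C(=C(O)/C=C/c2c(C)cc(C)cc2C)C(=O)C1(C)C`: 8.4 ug/mL

Compound 2 stands level with compound 1, and together they hold the lowest of the three numbers, while compound 3 reads higher at 8.4 ug/mL. The next structure, compound 4 `C=Cc1ccccc1/C=C/C(O)=C1/C(=O)C(C)=C(OC)C(C)(C)C1=O`, differs from compound 2 as follows: 2-vinylphenyl in place of 4-methylphenyl on a double-bonded chain carbon bound to a double-bonded chain carbon. Among the compounds with values here, the one measured step that exchanges the aromatic group at this place is no change at the digits printed from compound 1 to compound 2 (within the scatter). Compound 3 shows that a different aromatic group there can also give a higher number. In this assay the expected result is a 1.2-fold higher number from compound 2 to compound 4 (0.09 log units; within the scatter), so no clear step is anticipated. Compound 4 is estimated at 5 ug/mL, with an expected range of 2.5 ug/mL to 10 ug/mL.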

Compound 4, concentration for half-maximal effect: 2.1 ug/mL
Beside the measured number, compound 4's estimate is 2.4-fold (0.38 log units) above it; measured number below the stated range.
By their numbers in this assay, from the lowest: compounds 4, 1 and 2 (each within the scatter of the next); then compound 3.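

In this assay, 2-vinylphenyl on a double-bonded chain carbon bound to a double-bonded chain carbon gives a 2.0-fold lower number from compound 2 to compound 4 (0.29 log units; within the scatter). Vinyl in place of methoxy on an aromatic carbon gives a 2.0-fold lower number from compound 1 to compound 4 (0.29 log units; within the scatter), so a group with a double bond outside the aromatic ring at this place leaves the number within the scatter of both earlier compounds. Nothing measured here bears on the reason for either step. Open, from the compounds shown here alone, is whether an amine, a carboxylic acid or a longer chain on an aromatic carbon would give a step beyond the scatter.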